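Acylurea thiazole hydrazones: nitro to dichloro swap

The source may hold more compounds than are shown below. What is called first, only, known or untested is meant among the compounds shown, and "the series" means these compounds.

Measured so far:
compound 1 `CN(C(=O)NC(=O)c1ccc([N+](=O)[O-])cc1)c1nc(C(F)(F)F)c(C(=O)N/N=C/c2ccc([N+](=O)[O-])cc2)s1` — 12.3 ug/mL
compound 2 `CNc1nc(C(F)(F)F)c(C(=O)N/N=C/c2cccc(C(F)(F)F)c2)s1` — > 100 ug/mL

Within the data shown here, in a functional assay on HepG2 cells (Homo sapiens) for inhibition, read by MTT assay, with a stated time of 72 h (on this read-out higher numbers stand for weaker inhibition and lower numbers for stronger inhibition), compound 1 gives 12.3 ug/mL, the only numerical reading in the set. Compound 2 sits at the limit of > 100 ug/mL in this assay, at which 1 of the 2 values shown sits, so its reading is a limit and not a number. Among the measured compounds shown here, compound 1 and compound 2 differ in more than one place, so no step between measured compounds can be read; their two values show only that compound 1 has a number and compound 2 a limit.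

Compound 3 `CN(C(=O)NC(=O)c1ccc(Cl)c(Cl)c1)c1nc(C(F)(F)F)c(C(=O)N/N=C/c2ccc([N+](=O)[O-])cc2)s1` differs from compound 1 by 3,4-dichlorophenyl in place of 4-nitrophenyl on a carbonyl carbon. For the measured compounds named here, no measured step of this kind exists, so the step of a 1.2-fold higher number from compound 1 to compound 3 (0.09 log units; within the scatter) is expected to stay within the scatter, with no direction favoured. Compound 3 is therefore expected to give 15 ug/mL, with a range from 5 ug/mL to 50 ug/mL.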

Compound 3, half-maximal inhibitory concentration: 6.85 ug/mL
Compound 3: the middle estimate sits 2.2-fold (0.34 log units) above what was measured; low and high end bracket the measured number.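

Among these compounds, this is the first one-place comparison: in this assay, 3,4-dichlorophenyl in place of 4-nitrophenyl on a carbonyl carbon gives a 1.8-fold lower number from compound 1 to compound 3 (0.25 log units; within the scatter) and so leaves the two compounds indistinguishable on this read-out. A measurable reading therefore survives this exchange of the ring on the carbonyl carbon, with the rest of compound 1 unchanged. No measured property at hand bears on this step.

Still open, on these data alone, is how a plain phenyl, a 4-aminophenyl or a saturated ring such as cyclohexyl would read on the same carbonyl carbon, and whether an aromatic ring is needed there at all. As far as these compounds go, the role of the acylurea chain also stays open, since compound 2 differs from the others in more than one place and its reading is a limit.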